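The source may hold more compounds than are shown below. What is called first, only, known or untested is meant among the compounds shown, and "the series" means these compounds.

Measured compounds in a functional assay on M21 cells (Homo sapiens) for antiproliferative activity, read by sulforhodamine B assay, with a stated time of 48 h; on this read-out lower numbers stand for stronger inhibition and higher numbers for weaker inhibition:

- compound 1, `CCN1CCN(c2ccc(S(=O)(=O)Oc3cc(OC)cc(OC)c3)cc2)C1=O`, gives 4200 nM
- compound 2, `CCN1CCN(c2ccc(S(=O)(=O)Oc3cc(OC)c(OC)c(OC)c3)cc2)C1=O`, gives 870 nM
- compound 3, `CCCN1CCN(c2ccc(S(=O)(=O)Oc3cccc(OC)c3)cc2)C1=O`, gives 10000 nM

Compound 3 carries the highest number of the three, and its gap to each of the others lies beyond the scatter. The difference between the core of compound 1 and the core of compound 3 is not broken down here; they differ in more than one place.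

Among the compounds with values here, the single counted step so far is methoxy in place of hydrogen on an aromatic carbon, which gave a 4.8-fold lower number from compound 1 to compound 2 (0.68 log units; beyond the scatter).

Compound 4, `CCCN1CCN(c2ccc(S(=O)(=O)Oc3ccc(OC)c(OC)c3)cc2)C1=O`, is to be measured in this assay. It arises from compound 3 by methoxy in place of hydrogen on an aromatic carbon. This is the same kind of change as from compound 1 to compound 2, not the same: in compound 2 the entering methoxy is ortho to two methoxy groups, in compound 4 ortho to a methoxy group, in both para to a large group.

Within the data shown here, a step of broadly similar size is expected, a 3.3-fold lower number from compound 3 to compound 4 (0.52 log units; beyond the scatter), because the one precedent is a 4.8-fold lower number from compound 1 to compound 2 (0.68 log units; beyond the scatter), with some allowance for the differing surroundings. Compound 4 is therefore estimated at 3000 nM in this assay, expected to fall between 1000 nM and 8000 nM.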

Compound 4, half-maximal inhibitory concentration: 28000 nM
Compound 4: the middle estimate sits 9.3-fold (0.97 log units) below what was measured, and the stated range ends below it.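

In this assay, methoxy in place of hydrogen on an aromatic carbon gives a 2.8-fold higher number from compound 3 to compound 4 (0.45 log units; beyond the scatter). The change therefore does not carry from one core to the other in this series with a fixed size, or even a fixed direction: the same change on two cores in this assay, a 4.8-fold lower number (0.68 log units; beyond the scatter) from compound 1 to compound 2 and a 2.8-fold higher number (0.45 log units; beyond the scatter) from compound 3 to compound 4, 14-fold (1.13 log units) apart, beyond the scatter of two such steps This is a single pair of steps, and it does not show which feature sets the outcome: the core of compound 1 and the core of compound 3 differ in more than one place, and the entering methoxy is ortho to two methoxy groups in compound 2 but ortho to a methoxy group in compound 4.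

The compounds shown leave open whether the ethyl chain or the propyl chain on its own would alter the direction of this step, as no pair here differs in that chain alone. They also leave open how a hydroxy group or a fluorine atom on the same aromatic carbon would compare with methoxy on either core.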